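Amide-linked chain series: expectation for compound 4

This account rests on a few compounds, and the source may have more. Where it says the series, first, only, none or still open, it means among the compounds named here.

Three compounds share the core of compound 1 `Cn1c(Cc2nn(C)c(=O)c3ccccc23)nnc1SCCCCCCCC(=O)Oc1ccc(Cl)cc1Cl` and differ only in the group attached to the carbonyl carbon at the end of the chain. In an assay on isolated protein (Mus musculus) for inhibition of IL15-IL15 receptor (Homo sapiens), read by resazurin assay, with stated times of 30 min and 2.5 days (on this read-out lower numbers stand for stronger inhibition and higher numbers for weaker inhibition), compound 1 gives 800 nM. Compound 2 `CC(C)COc1ccc(NC(=O)CCCCCCCSc2nnc(Cc3nn(C)c(=O)c4ccccc34)n2C)cc1` gives 4800 nM in this assay, and compound 3 `CCCOc1ccc(NC(=O)CCCCCCCSc2nnc(Cc3nn(C)c(=O)c4ccccc34)n2C)cc1` gives 1600 nM. Compound 3 thus stands second highest of the three numbers: its step of a 2.0-fold higher number from compound 1 to compound 3 (0.30 log units; within the scatter) is within the scatter, while a 3.0-fold lower number from compound 2 to compound 3 (0.48 log units; beyond the scatter) is beyond it and counts as modest.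

Compound 4 `Cn1c(Cc2nn(C)c(=O)c3ccccc23)nnc1SCCCCCCCC(=O)Nc1ccccc1O` is not yet measured. Relative to compound 3 the change is 2-hydroxyphenyl in place of 4-propoxyphenyl on an amide-type nitrogen. Among the compounds with values here, no measured step touches this change directly. a 2.0-fold higher number from compound 1 to compound 3 (0.30 log units; within the scatter) only shows that the (4-propoxyphenyl)amino amide and the 2,4-dichlorophenoxy group give numbers within the scatter of each other, and a 3.0-fold lower number from compound 2 to compound 3 (0.48 log units; beyond the scatter) shows a modest shift for hydrogen in place of methyl on a saturated chain carbon. The move from 4-propoxyphenyl to 2-hydroxyphenyl is larger than either, so the direction is uncertain; a step of roughly the scatter's edge toward a higher number is expected, a 1.6-fold higher number from compound 3 to compound 4 (0.19 log units; within the scatter). Compound 4 is estimated at 2500 nM, with a range from 900 nM to 7000 nM.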

Compound 4, half-maximal inhibitory concentration: 27000 nM
Compound 4: the middle estimate sits 11-fold (1.03 log units) below what was measured; measured number above the stated range.
By their numbers in this assay, from the lowest: compounds 1 and 3 (each within the scatter of the next); then compound 2; then compound 4.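

In this assay, within the data shown here, the group on the amide-type nitrogen turns out to matter far more than the earlier compounds suggested: a 17-fold higher number from compound 3 to compound 4 (1.23 log units; beyond the scatter) is a large step, whereas the earlier changes at this end of the chain were modest or within the scatter. The 2-hydroxyphenyl amide also stands apart from the other two end groups, with a 5.6-fold higher number from compound 2 to compound 4 (0.75 log units; beyond the scatter) and a 34-fold higher number from compound 1 to compound 4 (1.53 log units; beyond the scatter), so compound 4 has the highest number of the four, and its steps to all the others lie beyond the scatter. No accompanying measurement explains the size of these steps.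

The change from 4-propoxyphenyl to 2-hydroxyphenyl alters the group and its ring position in one move, so the compounds shown do not separate the hydroxy group, its position and the loss of the propoxy chain; 4-hydroxyphenyl, 2-propoxyphenyl and unsubstituted phenyl on the same nitrogen would divide these contributions. Also open, as far as these compounds go, is whether 2-methoxyphenyl, which keeps the oxygen but not the hydroxyl hydrogen, gives a number close to that of compound 4 or one closer to that of compound 3.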